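This account rests on a few compounds, and the source may have more. Where it says the series, first, only, none or still open, it means among the compounds named here.

Measured in a functional assay on THP-1 cells (Homo sapiens) for cytotoxicity, read by MTT assay, with a stated time of 24 h; a lower number here means a stronger inhibitor, a higher number a weaker inhibitor:
- Compound 1 `C=C1CC[C@H]2C(C)(C)CCC[C@]2(C)[C@H]1CCC(C)CC(=O)O`: > 200000 nM (a limit)
- Compound 2 `Cc1ccc(/C=C2\CC[C@H]3C(C)(C)CCC[C@]3(C)[C@H]2CCC(C)CC(=O)O)cc1`: > 200000 nM (a limit)

Compound 2 stands at a limit, > 200000 nM, so it has no exact number. Going by the values given here, the only guide is the limit of > 200000 nM in this assay, at which 2 of the 2 values shown sit. Compound 3 `COc1ccc(/C=C2\CC[C@H]3C(C)(C)CCC[C@]3(C)[C@H]2CCC(C)CC(=O)O)cc1OC` carries 3,4-dimethoxyphenyl in place of 4-methylphenyl on a double-bonded chain carbon bound to a double-bonded ring carbon. Among the compounds with values here, no measured step shows what this swap does, so no change beyond the scatter is expected in this assay. The expected step is a number no higher from compound 2 to compound 3 (the limit leaves the size open). For compound 3 the estimate is 200000 nM, with an expected range from 100000 nM to 400000 nM.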

Compound 3, half-maximal inhibitory concentration: 178000 nM
For compound 3 the middle estimate is 1.1-fold (0.05 log units) above the measured one; the range from low to high includes it.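

In this assay, 3,4-dimethoxyphenyl in place of 4-methylphenyl gives an at least 1.1-fold lower number from compound 2 to compound 3 (0.05 log units; that floor lies within the scatter). Compound 3 provides the first exact number among the compounds shown, 178000 nM, so this position can carry a change that yields a measurable value, though the true size of the step remains unknown and it may lie within the scatter. Limits still dominate the series: the limit of > 200000 nM in this assay, at which 2 of the 3 values shown sit.

From the compounds shown here alone, it remains open whether an amine or a hydroxyl group on this aromatic ring would move the number further. Going by these compounds, it also remains open whether a single methoxy group would give a similar value.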